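A hydroxymethyl step from compound 2 to compound 3

The source may report more compounds than this note shows. Statements on the series, on what has been measured and on what is new or still open speak of the compounds shown alone.

Measured in a functional assay on HeLa cells (Homo sapiens) for inhibition; on this read-out lower numbers stand for stronger inhibition and higher numbers for weaker inhibition:
- Compound 1 `Nc1ccn(/C=C/C=O)c(=O)n1`: > 100000 nM (a limit of the assay)
- Compound 2 `O=C/C=C/n1ccc(=O)[nH]c1=O`: 30000 nM

Among the compounds with values here, of these two results, only one is an actual number. In this assay compound 2 gives 30000 nM. The result for compound 1 is a limit, so no step can be read from the pair.

Compound 3 `O=C/C=C/n1cc(CO)c(=O)[nH]c1=O`, not yet measured, comes from compound 2 through a single change, hydroxymethyl in place of hydrogen on an aromatic carbon. Within the data shown here, no measured pair tests a change at this place, so the expectation rests on compound 2 at 30000 nM alone. In this assay no shift beyond the usual scatter is expected, and the expected 1.2-fold lower number from compound 2 to compound 3 (0.08 log units; within the scatter) has no firm direction. For compound 3 the estimate is 25000 nM, with an expected range from 8000 nM to 80000 nM.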

Compound 3, half-maximal inhibitory concentration: > 100000 nM
Compound 3: only a limit was reported; the forecaster's own chance of this, stated with the estimate: 15%; middle value at least 4.0-fold (0.60 log units) from the limit.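

In this assay, within the data shown here, the step is the first reading at this position: hydroxymethyl in place of hydrogen on the aromatic carbon meta to the 2-formylethenyl group gives an at least 3.3-fold higher number from compound 2 to compound 3 (0.52 log units; beyond the scatter). The position is therefore not indifferent to this change, since this single replacement moves the read-out beyond the scatter towards weaker inhibition. Compound 3 gives > 100000 nM, which is a limit of the assay and not a number, so the step fixes only a minimum size and its true size stays unknown: the limit of > 100000 nM in this assay, at which 2 of the 3 values shown sit.

The compounds shown leave open whether the weaker inhibition belongs to hydroxymethyl itself or would also follow from another group on this carbon, such as a methyl, a fluorine or a carboxylic acid. They also leave open how hydroxymethyl at this place would act on the core of compound 1, which carries an amine.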